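The compounds below may be only part of what the source reports. "The series", "measured", "known", "first", "only" and "open" are said of these compounds alone.

Among the compounds with values here, in a functional assay on MCF7 cells (Homo sapiens) for antiproliferative activity (on this read-out higher numbers stand for weaker inhibition of growth and lower numbers for stronger inhibition of growth), compound 1 `COc1ccc(-c2nc3ccccc3s2)cc1OC` gives 52700 nM, the highest of the two numbers so far. Compound 2 `COc1cc(-c2nc3cc(F)ccc3s2)cc(O)c1OC` gives 653 nM, lower by a margin well beyond the scatter. Compound 2 differs from compound 1 in more than one place, so the gap between them cannot be assigned to any single change. Compound 3 `COc1ccc(-c2nc3cc(Cl)ccc3s2)cc1OC` keeps the core of compound 1 and takes chloro in place of hydrogen on an aromatic carbon, (chloro in place of hydrogen on an aromatic carbon). Within the data shown here, no single-site step has been measured in this assay to guide the expectation. A clear drop beyond the scatter, toward stronger inhibition of growth, is expected, resting loosely on the fluoro-bearing compound 2 at 653 nM. The estimated step is a 180-fold lower number from compound 1 to compound 3 (2.24 log units; beyond the scatter). For compound 3 the expected value is 300 nM, with an estimated range of 2 nM to 20000 nM.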

Compound 3, concentration for 50% growth inhibition: 27900 nM
Estimate against measurement, compound 3: 93-fold (1.97 log units) below, and the stated range ends below it.
By their numbers in this assay, from the lowest: compound 2; then compounds 3 and 1 (each within the scatter of the next).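

In this assay, chloro in place of hydrogen on this aromatic carbon gives the first single-site step available, a 1.9-fold lower number from compound 1 to compound 3 (0.28 log units; within the scatter), and that step lies within the scatter. Compound 3 and compound 1 therefore cannot be told apart on this read-out, so on the core of compound 1 this one change at this position shows no measurable effect on inhibition of growth. No measurement shown here offers an explanation for this result.

On these data alone, whether an amine or a carboxylic acid on the same aromatic carbon would leave the number equally unmoved remains open. Within the data shown here, also open is which of the several differences between compound 2, at 653 nM, and compound 1 carries the gap between them, since no single-site step separates that pair.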